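The source may hold more compounds than are shown below. What is called first, only, known or untested is meant among the compounds shown, and "the series" means these compounds.

Working notes on the series. The shared core of compound 1, `CC(C)C(Nc1nccs1)c1ccc(-c2ccc3cccc(F)c3c2)[nH]c1=O`, carries its variable group on a saturated chain carbon bound to an aromatic carbon and a saturated chain carbon. Among the measured compounds shown here, in a functional assay on CHO cells for antagonist activity at prostaglandin E2 receptor EP3 subtype (Homo sapiens), read by cAMP accumulation (a higher number here means a weaker inhibitor, a lower number a stronger inhibitor), compound 1 gives 10 nM, the highest of the two numbers measured so far. Compound 2, `CC(C)C(/C=C1\CCNC1=O)c1ccc(-c2ccc3cccc(F)c3c2)[nH]c1=O`, differs from compound 1 only at that carbon; in this assay compound 2 gives 8.7 nM, and the step of a 1.1-fold lower number from compound 1 to compound 2 (0.06 log units; within the scatter) lies within the scatter. Compound 3, `CC(C)C(c1ncco1)c1ccc(-c2ccc3cccc(F)c3c2)[nH]c1=O`, is not yet measured; it differs from compound 1 by 1,3-oxazol-2-yl in place of (1,3-thiazol-2-yl)amino on a saturated chain carbon bound to an aromatic carbon and a saturated chain carbon. For the measured compounds named here, the only measured step that bears on this position is a 1.1-fold lower number from compound 1 to compound 2 (0.06 log units; within the scatter), which shows that exchanging the group at this carbon need not move the number beyond the scatter. Compound 3 is therefore expected to lie close by, with the step of a 1.5-fold higher number from compound 1 to compound 3 (0.18 log units; within the scatter) expected to be small in either direction. The estimate for compound 3 in this assay is 15 nM, expected to fall between 5 nM and 50 nM.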

Compound 3, half-maximal inhibitory concentration: 64 nM
Compound 3: middle estimate off by 4.3-fold (0.63 log units), on the low side; measured number outside the range, above it.
By their numbers in this assay, from the lowest: compounds 2 and 1 (each within the scatter of the next); then compound 3.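

In this assay this carbon proves not to be indifferent to its group: the step of a 6.4-fold higher number from compound 1 to compound 3 (0.81 log units; beyond the scatter) lies beyond the scatter, and so does a 7.4-fold higher number from compound 2 to compound 3 (0.87 log units; beyond the scatter) at the same position. The earlier pair suggested tolerance, but that tolerance does not extend to 1,3-oxazol-2-yl, which matches neither (1,3-thiazol-2-yl)amino nor the five-membered non-aromatic ring group of compound 2. Nothing measured on these compounds accounts for the higher number of compound 3.

The step to compound 3 changes the ring and removes the amino link in a single exchange, so the compounds shown do not separate these two changes. A plain 1,3-thiazol-2-yl group or a (1,3-oxazol-2-yl)amino group on this carbon would tell them apart.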